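Cyclohexyl for Nonyl on the Urea Nitrogen

This account rests on a few compounds, and the source may have more. Where it says the series, first, only, none or still open, it means among the compounds named here.

Three compounds share one core: a triazole-bearing nitrogen that carries a dimethoxybenzyl group and a urea. Compound 1 `COc1ccc(CN(C(=O)Nc2ccc(Cl)cc2)n2cnnc2)cc1OC` and compound 2 `COc1ccc(OC)c(CN(C(=O)Nc2ccc(C)cc2)n2cnnc2)c1` hold an aromatic ring on the amide-type nitrogen, while compound 3 `CCCCCCCCCNC(=O)N(Cc1cc(OC)ccc1OC)n1cnnc1` holds a nonyl chain there. In a functional assay on DU-145 cells (Homo sapiens) for cytotoxicity, read by MTT assay, with a stated time of 48 h (a higher number here means a weaker inhibitor, a lower number a stronger inhibitor), compound 1 gives 20400 nM and compound 2 gives 20900 nM. From the compounds shown here alone, for compound 3 the this assay reports only a limit, > 50000 nM, so its true number is unknown and it sits at the limit of > 50000 nM in this assay, at which 1 of the 3 values shown sits. Within the data shown here, the single measured step at this position, an at least 2.3-fold higher number from compound 2 to compound 3 (0.37 log units; beyond the scatter), shows a weakening when the aromatic ring gives way to the chain.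

Compound 4 `COc1ccc(OC)c(CN(C(=O)NC2CCCCC2)n2cnnc2)c1` differs from compound 3 by cyclohexyl in place of nonyl on an amide-type nitrogen. Among the measured compounds shown here, the incoming ring is saturated, so it resembles neither the aromatic ring of compound 2 nor the long chain of compound 3 exactly, and no measured step covers this exchange. Because compound 3 stands only at > 50000 nM, the size of the step cannot be fixed closely. Compound 4 is expected to give about 38000 nM, in a range from 15000 nM to 80000 nM, which would mean an estimated step of an at least 1.3-fold lower number from compound 3 to compound 4 (0.11 log units; that floor lies within the scatter).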

Compound 4, half-maximal inhibitory concentration: 29800 nM
Compound 4: the middle estimate sits 1.3-fold (0.11 log units) above what was measured; low and high end bracket the measured number.
By their numbers in this assay, from the lowest: compounds 1, 2 and 4 (each within the scatter of the next). At a limit, above all of these: compound 3.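

Cyclohexyl in place of 4-methylphenyl gives a 1.4-fold higher number from compound 2 to compound 4 (0.15 log units; within the scatter), so on this amide-type nitrogen an aromatic ring is not needed for a number of this size in this assay. Cyclohexyl in place of nonyl gives an at least 1.6-fold lower number from compound 3 to compound 4 (0.22 log units; that floor lies within the scatter), and a floor within the scatter does not by itself establish that the ring gives a lower number than the chain. The true size of that step stays unknown because compound 3 has only a limit: the limit of > 50000 nM in this assay, at which 1 of the 4 values shown sits.

The compounds shown leave open where a shorter chain such as butyl, or a smaller ring such as cyclopentyl, would fall on this nitrogen. They also leave open what an amine or a carboxylic acid on the cyclohexyl ring of compound 4 would do to the number.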